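The source may report more compounds than this note shows. Statements on the series, on what has been measured and on what is new or still open speak of the compounds shown alone.

Compound 1 `CCC(=O)N(c1cccc(OC)c1)C1CCCC1N(C)C` gives 4 mg/kg
Compound 2 `CCC(=O)N(c1cccc(Cl)c1)C1CCCC1N(C)C` gives 20 mg/kg
Compound 3 `CCC(=O)N(c1cc(Cl)cc(Cl)c1)C1CCCC1N(C)C` gives 30 mg/kg

In a functional assay on the whole organism for positive allosteric modulation, with Mus musculus as the target (a lower number here means that less compound is needed, a higher number that more compound is needed for the effect), compound 3 gives 30 mg/kg and sits within the scatter of compound 2, while compound 1 needs clearly less, at 4 mg/kg here. Compound 4 `CCC(=O)N(c1cc(Cl)c(Cl)c(Cl)c1)C1CCCC1N(C)C` differs from compound 3 by one change (chloro in place of hydrogen on an aromatic carbon): chloro in place of hydrogen on an aromatic carbon, ortho to two chloro groups. The nearest guide is the same replacement of hydrogen by chloro (a 1.5-fold higher number from compound 2 to compound 3 (0.18 log units; within the scatter)). The replacement of methoxy by chloro (a 5.0-fold higher number from compound 1 to compound 2 (0.70 log units; beyond the scatter)) was larger, but it is a different change. No step beyond the scatter is therefore expected, and the estimated change is small (a 1.2-fold higher number from compound 3 to compound 4 (0.07 log units; within the scatter)). For compound 4 the expected value is 35 mg/kg within an estimated range from 15 mg/kg to 80 mg/kg in this test.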

Compound 4, dose for half-maximal effect: 40 mg/kg
For compound 4 the middle estimate is 1.1-fold (0.06 log units) below the measured one; measured number inside the range.
By their numbers in this assay, from the lowest: compound 1; then compounds 2, 3 and 4 (each within the scatter of the next).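

In this assay, a chloro group ortho to two chloro groups and para to a large group gives a step within the scatter (a 1.3-fold higher number from compound 3 to compound 4 (0.12 log units; within the scatter)). This position therefore accepts chloro in place of hydrogen without a clear shift in dose, even with both neighbouring chloro groups already present. No measurement shown gives a reason for this result. Open, from the compounds shown here alone, is whether an amine or a carboxylic acid at this position would shift the dose beyond the scatter. Also open, going by these compounds, is whether a hydroxyl group in place of the methoxy of compound 1 would keep its lower number.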